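The source may report more compounds than this note shows. Statements on the series, on what has been measured and on what is new or still open speak of the compounds shown alone.

In a functional assay on K562 cells (Homo sapiens) for cytotoxicity, read by sulforhodamine B assay (a lower number here means a stronger inhibitor of growth, a higher number a weaker inhibitor of growth), compound 3 `CC1=CC[C@@H]([C@@](C)(O)CCCC(C)(C)NC(=S)N/N=C\c2cccc(Cl)c2)CC1` gives 30 nM and stands lowest of the three numbers measured; compound 2 `CC1=CC[C@@H]([C@@](C)(O)CCCC(C)(C)NC(=S)N/N=C\c2ccccc2Cl)CC1` gives 150 nM and compound 1 `CC1=CC[C@@H]([C@@](C)(O)CCCC(C)(C)NC(=S)N/N=C\c2ccc(O)cc2)CC1` gives 600 nM. Both steps to compound 3 are beyond the scatter: a 5.0-fold lower number from compound 2 to compound 3 (0.70 log units; beyond the scatter) and a 20-fold lower number from compound 1 to compound 3 (1.30 log units; beyond the scatter), and the smaller step of a 4.0-fold lower number from compound 1 to compound 2 (0.60 log units; beyond the scatter) links the other two. Compound 4 `CC1=CC[C@@H]([C@@](C)(O)CCCC(C)(C)NC(=S)N/N=C(/C)c2ccccc2)CC1` differs from compound 3 by a group of 9 heavy atoms (8 carbon, 1 nitrogen; one six-membered aromatic ring of carbon only) in place of a group of 9 heavy atoms (7 carbon, 1 nitrogen, 1 chlorine; one six-membered aromatic ring of carbon only), on an amide-type nitrogen, so the chlorine on the ring is gone and a methyl sits on the carbon with the double bond to nitrogen. Going by the values given here, no measured step removes a chlorine or adds that methyl, but the steps from compound 1 and compound 2 to compound 3 show that the ring pattern in this part of the molecule moves this assay a lot, and compound 3 holds the lowest number. A change away from that pattern is therefore expected to raise the number, by a modest step of a 6.7-fold higher number from compound 3 to compound 4 (0.82 log units; beyond the scatter). Compound 4 is estimated at 200 nM, within a range from 50 nM to 800 nM.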

Compound 4, concentration for 50% growth inhibition: 10 nM
Compound 4: middle estimate off by 20-fold (1.30 log units), on the high side, outside the stated range (below it).
By their numbers in this assay, from the lowest: compound 4; then compound 3; then compound 2; then compound 1.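

In this assay the group on the amide-type nitrogen can do without a chlorine on the ring: with the chlorine gone and a methyl on the carbon with the double bond to nitrogen, the number still falls, by a 3.0-fold lower number from compound 3 to compound 4 (0.48 log units; beyond the scatter). The same group also gives larger drops against the other two ring patterns, with a 15-fold lower number from compound 2 to compound 4 (1.18 log units; beyond the scatter) and a 60-fold lower number from compound 1 to compound 4 (1.78 log units; beyond the scatter), so the earlier ring comparisons did not mark the lower limit of this series. No supporting data here explain why this change lowers the number.

As far as these compounds go, since the chlorine leaves and the methyl enters in one step, the share of each in the drop stays open. Also open, from the compounds shown here alone, are the results for a 3-chlorophenyl ring keeping that methyl, and for an ethyl group in the methyl's place.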